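Epimer at a chain stereocentre in the prostanoid-type series

The compounds below may be only part of what the source reports. "The series", "measured", "known", "first", "only" and "open" are said of these compounds alone.

Measured so far:
- compound 1 `CCCC[C@](C)(OC)[C@@H](O)/C=C/C1[C@H](O)CC(=O)[C@@H]1C/C=C\CCCC(=O)OC`: 0.912 mg/kg
- compound 2 `CCCC[C@](C)(OC)[C@H](O)/C=C/C1[C@H](O)C[C@H](O)[C@@H]1C/C=C\CCCC(=O)OC`: 1.82 mg/kg
- compound 3 `CCCC[C@@](C)(OC)[C@@H](O)/C=C/C1[C@H](O)CC(=O)[C@@H]1CCCCCCC(=O)OC`: > 4 mg/kg

In a functional assay on the whole organism with Mus musculus as the target (on this read-out lower numbers stand for an effect already at smaller amounts and higher numbers for an effect only at larger amounts of compound), compound 1 gives 0.912 mg/kg. Compound 2 gives 1.82 mg/kg in this assay, the highest of the two numbers, but its nearest neighbour, compound 1, differs only within the usual scatter, so the two cannot be ordered. For compound 3 this assay reports only a limit, > 4 mg/kg; (the limit of > 4 mg/kg in this assay, at which 1 of the 3 values shown sits). Compound 3 differs from compound 2 in more than one place, so its limit says nothing about any single change.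

Compound 4 `CCCC[C@](C)(OC)[C@@H](O)/C=C/C1[C@H](O)C[C@H](O)[C@@H]1C/C=C\CCCC(=O)OC` is not yet measured. It differs from compound 2 in this way: the two compounds have the same atoms and bonds; at least one stereo element is drawn with a configuration in one of them and without one in the other: 1 of 8 stereo elements differ; a stereocentre at a saturated chain carbon is drawn R in compound 2 and S in compound 4. Among the compounds with values here, no step between measured compounds isolates this change, so no measured size can be assigned to it.

The expectation is that the step of a 1.1-fold lower number from compound 2 to compound 4 (0.06 log units; within the scatter) stays within the scatter, in no clear direction. Compound 4 is therefore estimated at 1.6 mg/kg in this assay, with a range from 0.6 mg/kg to 4 mg/kg.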

Compound 4, dose for half-maximal effect: > 4 mg/kg
Compound 4 gave a limit, no number; the forecaster's own chance of this, stated with the estimate: 20%; middle value at least 2.5-fold (0.39 log units) from the limit.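

In this assay compound 4 gives > 4 mg/kg, which is a limit and not a number. Within the data shown here, the change from R to S at a saturated chain carbon, with atoms and bonds unchanged, is the first single change that can be read, and it gives an at least 2.1-fold higher number from compound 2 to compound 4 (0.34 log units; beyond the scatter). The configuration at this chain stereocentre therefore matters in this assay, although the reading carries one reservation about how the pair is drawn: the fact that one of compounds 2 and 4 is drawn with a defined configuration and the other without, at the place where they differ

As far as these compounds go, the true size of the step stays open, since it ends at a limit. Also open, from the compounds shown here alone, is whether this stereocentre matters to the same degree in compounds with the ring carbonyl of compound 1, with a carboxylic acid in place of the ester, or with a longer chain.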